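A Bromophenyl Variant of a Triazole-Linked Indole Ester

The source may hold more compounds than are shown below. What is called first, only, known or untested is meant among the compounds shown, and "the series" means these compounds.

Compound 1 `Cc1cccc(-n2cc(COC(=O)c3cc4ccccc4[nH]3)nn2)c1C` gives 15300 nM in an ADME assay on HEK293 cells (Homo sapiens) for cytotoxicity, read by MTT assay, with a stated time of 48 h; a lower number here means a stronger inhibitor, a higher number a weaker inhibitor.
Compound 2 `COc1ccc(-n2cc(COC(=O)c3cc4ccccc4n3Cc3cn(-c4ccc(OC)cc4)nn3)nn2)cc1` gives 43900 nM in this assay.
Compound 3 `Cc1cc(C)cc(-n2cc(COC(=O)c3cc4ccccc4n3Cc3cn(-c4cc(C)cc(C)c4)nn3)nn2)c1` gives 50200 nM in this assay.

Compound 1 holds the lowest number of the three; compound 2 and compound 3 both stand higher, each beyond the scatter. Compound 4 `O=C(OCc1cn(-c2ccccc2Br)nn1)c1cc2ccccc2[nH]1` differs from compound 1 by 2-bromophenyl in place of 2,3-dimethylphenyl on an aromatic nitrogen, while the rest of the shared core stays as it is. Going by the values given here, no pair among the measured compounds shows a change of this kind, so the step is expected to be small: the step of a 1.2-fold higher number from compound 1 to compound 4 (0.07 log units; within the scatter) is expected to fall within the scatter, with no clear direction. Compound 4 is accordingly estimated at 18000 nM, with a range from 7000 nM to 45000 nM.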

Compound 4, half-maximal inhibitory concentration: > 200000 nM
Compound 4: only a limit was reported; the forecaster's own chance of this, stated with the estimate: 15%; middle value at least 11-fold (1.04 log units) from the limit.
By their numbers in this assay, from the lowest: compound 1; then compounds 2 and 3 (each within the scatter of the next). At a limit, above all of these: compound 4.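

On the aromatic nitrogen, the aryl group proves far from interchangeable: 2-bromophenyl in place of 2,3-dimethylphenyl gives an at least 13-fold higher number from compound 1 to compound 4 (1.11 log units; beyond the scatter). In this assay compound 4 gives > 200000 nM, which is a limit of the assay and not a number. As far as these compounds go, the full size of the step therefore stays unknown, for it rests on a limit: the limit of > 200000 nM in this assay, at which 1 of the 4 values shown sits. The compounds shown leave open how 2-methylphenyl or 2-chlorophenyl would read at this position, and so whether the step follows the bromine or the loss of the methyl groups.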